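Methoxy on the Benzyl Ring of a Benzothiazole Acetamide

The source may hold more compounds than are shown below. What is called first, only, known or untested is meant among the compounds shown, and "the series" means these compounds.

Measured compounds in a functional assay on HepG2 cells (Homo sapiens) for cytotoxicity, read by MTT assay, with a stated time of 48 h; on this read-out lower numbers stand for stronger inhibition and higher numbers for weaker inhibition:
compound 1 `COc1ccc(CNC(=O)CSc2nc3ccc(NC(=O)c4ccccc4OC)cc3s2)cc1`, 2100 nM
compound 2 `O=C(CSc1nc2ccc(NC(=O)CCl)cc2s1)NCc1ccc(Cl)cc1`, 1800 nM
compound 3 `O=C(CSc1nc2ccc(NC(=O)CCl)cc2s1)NCc1ccccc1`, 1100 nM

Compound 3 gives 1100 nM in this assay. Compound 2 gives 1800 nM, and the step of a 1.6-fold lower number from compound 2 to compound 3 (0.21 log units; within the scatter) stays within the scatter. For the measured compounds named here, compound 1 gives 2100 nM, also within the scatter of compound 3, though it differs from compound 3 in two places and no single step links them. Compound 4 `COc1ccc(CNC(=O)CSc2nc3ccc(NC(=O)CCl)cc3s2)cc1` differs from compound 3 by methoxy in place of hydrogen on an aromatic carbon, on an aromatic carbon of a six-membered aromatic ring of carbon only, para to a large group. Going by the values given here, the only step that bears on it, a 1.6-fold lower number from compound 2 to compound 3 (0.21 log units; within the scatter), exchanged a group at that same place without moving the number beyond the scatter. Compound 4 is therefore expected to show a 1.4-fold higher number from compound 3 to compound 4 (0.13 log units; within the scatter), no step beyond the scatter. The estimate for compound 4 is 1500 nM, with a range from 700 nM to 3500 nM.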

Compound 4, half-maximal inhibitory concentration: 2000 nM
For compound 4 the middle estimate is 1.3-fold (0.12 log units) below the measured one; the range from low to high includes it.
By their numbers in this assay, from the lowest: compounds 3, 2, 4 and 1 (each within the scatter of the next).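

In this assay, a third group at this place on the ring leaves the picture unchanged: a 1.8-fold higher number from compound 3 to compound 4 (0.26 log units; within the scatter) and a 1.1-fold higher number from compound 2 to compound 4 (0.05 log units; within the scatter) both stay within the scatter, so hydrogen, chloro and methoxy cannot be told apart here. The other end of the molecule now has a single step too, and with chloromethyl in place of 2-methoxyphenyl on the carbonyl carbon, a 1.1-fold lower number from compound 1 to compound 4 (0.02 log units; within the scatter) also stays within the scatter. No measurement given here speaks to the reason for these results.

From the compounds shown here alone, whether an amine or a carboxylic acid at this place on the ring would move the number beyond the scatter remains open.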